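A few compounds are considered here, and "the series" means these few. Any claim that something is new, unique, unknown or untested is made for them only; others in the source may bear on it.

Measured compounds in an assay on CHO-K1 cells for antagonist activity at transient receptor potential cation channel subfamily V member 1 (Homo sapiens), read by FLIPR; on this read-out lower numbers stand for stronger inhibition and higher numbers for weaker inhibition:
compound 1 `CC1CCN(CCCSc2nc(C(F)(F)F)ccc2CNC(=O)C(C)c2ccc(NS(C)(=O)=O)c(F)c2)CC1`, 217 nM
compound 2 `CC1CCC(Sc2nc(C(F)(F)F)ccc2CNC(=O)C(C)c2ccc(NS(C)(=O)=O)c(F)c2)CC1`, 180 nM
compound 3 `CC(C(=O)NCc1ccc(C(F)(F)F)nc1SCc1ccc(Cl)cc1)c1ccc(NS(C)(=O)=O)c(F)c1`, 674 nM

Compound 3 gives the highest of the three numbers in this assay. Against compound 1 the step is a 3.1-fold higher number from compound 1 to compound 3 (0.49 log units; beyond the scatter); against compound 2 it is a 3.7-fold higher number from compound 2 to compound 3 (0.57 log units; beyond the scatter). Compound 1 and compound 2 sit within the scatter of each other: a 1.2-fold lower number from compound 1 to compound 2 (0.08 log units; within the scatter).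

Compound 4 `COc1ccc(CSc2nc(C(F)(F)F)ccc2CNC(=O)C(C)c2ccc(NS(C)(=O)=O)c(F)c2)cc1` keeps the core of compound 3 and differs in one place: methoxy in place of chloro on an aromatic carbon. Going by the values given here, none of the measured steps changes a substituent on the six-membered aromatic ring of carbon only; the steps from compound 1 and from compound 2 to compound 3 replace the whole group on the sulfur, and their size says nothing about swapping chloro for methoxy on that ring. Among the compounds with values here, with no step of this kind among the measured compounds, the expectation for compound 4 is a number close to that of compound 3, with no step beyond the scatter in this assay in either direction. Compound 4 is therefore estimated at 700 nM, range 300 nM to 1600 nM. The estimated step from compound 3 to compound 4 is a 1.0-fold higher number from compound 3 to compound 4 (0.02 log units; within the scatter), that is, none beyond the scatter.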

Compound 4, half-maximal inhibitory concentration: 279 nM
Estimate against measurement, compound 4: 2.5-fold (0.40 log units) above; measured number outside the range, below it.
By their numbers in this assay, from the lowest: compounds 2, 1 and 4 (each within the scatter of the next); then compound 3.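

In this assay, going by these compounds alone, the substituent on the aromatic carbon para to a large group is not silent: methoxy in place of chloro gives a 2.4-fold lower number from compound 3 to compound 4 (0.38 log units; beyond the scatter), a modest step but one beyond the scatter, and the first measured change at this place. With the 4-methoxybenzyl group on the sulfur, the gaps seen for compound 3 no longer appear, with a 1.6-fold higher number from compound 2 to compound 4 (0.19 log units; within the scatter) and a 1.3-fold higher number from compound 1 to compound 4 (0.11 log units; within the scatter), both within the scatter, so the weaker number of compound 3 does not extend to every substituted benzyl group on the sulfur. No measurement shown accounts for the step between chloro and methoxy at this place.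

Still open, on these data alone, is whether the step is particular to methoxy, or whether fluoro, methyl, hydroxy or a dimethylamino group at the same place would read like compound 3 or like compound 4, and where the unsubstituted benzyl group would fall. A single pair also leaves open whether the same swap gives a step of this size with a longer chain between the sulfur and the aromatic ring.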